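This account rests on a few compounds, and the source may have more. Where it says the series, first, only, none or still open, it means among the compounds named here.

Measured so far in a physicochemical assay for solubility; a lower number here means a less soluble compound, a higher number a more soluble compound:
- compound 1 `CCOc1ccc2c(c1)C(c1cnn(C)c1)=CN(C)C(=O)[C@@H]2C`: 143 ug/mL
- compound 2 `CCOc1ccc2c(c1)C(c1c[nH]cn1)=CN(C)C(=O)[C@@H]2C`: >= 131 ug/mL (a limit of the assay)
- compound 3 `CCOc1ccc2c(c1)C(c1c[nH]c(C)n1)=CN(C)C(=O)[C@@H]2C`: >= 135 ug/mL (a limit of the assay)

Compound 3 has no exact value, only a limit: the limit of >= 135 ug/mL in this assay, at which 1 of the 3 values shown sits. Compound 2 is in the same position, with a limit of its own: the limit of >= 131 ug/mL in this assay, at which 1 of the 3 values shown sits. Compound 1 is therefore the only one of the three with a true number.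

The next compound keeps the shared core and changes only the group on a double-bonded ring carbon of the seven-membered ring. In compound 4 `CCOc1ccc2c(c1)C(c1cn(C)cn1)=CN(C)C(=O)[C@@H]2C`, 1-methyl-1H-imidazol-4-yl replaces 2-methyl-1H-imidazol-4-yl: 1-methyl-1H-imidazol-4-yl in place of 2-methyl-1H-imidazol-4-yl on a double-bonded ring carbon.

Within the data shown here, three measured steps bear on this swap: a step that the limit leaves unreadable from compound 1 to compound 2, a step that the limit leaves unreadable from compound 1 to compound 3 and a step that the two limits leave unreadable from compound 2 to compound 3. None of them has a size that can be read, so they give only weak guidance. The estimate must lean on the single firm figure, compound 1 at 143 ug/mL. Changes to this group have so far shown no readable shift, so no change beyond the usual scatter is expected in this assay. The expected change is a number no higher from compound 3 to compound 4 (the limit leaves the size open). Compound 4 is expected to give about 135 ug/mL, with an estimated range of 80 ug/mL to 175 ug/mL.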

Compound 4, solubility: 117 ug/mL
Beside the measured number, compound 4's estimate is 1.2-fold (0.06 log units) above it; low and high end bracket the measured number.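

Among these compounds, compound 4 gives the first step at this position whose size can be read in this assay: with 1-methyl-1H-imidazol-4-yl in place of 1-methyl-1H-pyrazol-4-yl, the result is a 1.2-fold lower number from compound 1 to compound 4 (0.09 log units; within the scatter). It also tests a methyl on the aromatic nitrogen, where the entering group counts 0 hydrogen-bond donors, and this gives an at least 1.1-fold lower number from compound 2 to compound 4 (0.04 log units; that floor lies within the scatter), while the swap of 2-methyl-1H-imidazol-4-yl for 1-methyl-1H-imidazol-4-yl gives an at least 1.1-fold lower number from compound 3 to compound 4 (0.06 log units; that floor lies within the scatter); both of these are floors rather than sizes, and neither floor goes beyond the scatter. Among the compounds shown here, the steps among compound 1, compound 2 and compound 3 still cannot be read, so the pair of compound 1 and compound 4 is the only firm comparison, and it shows two different five-membered aromatic rings with no difference beyond the scatter.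

As far as these compounds go, compound 3 still has only a limit, so its true distance from compound 4 stays open: the limit of >= 135 ug/mL in this assay, at which 1 of the 4 values shown sits. Also open is whether a different kind of group on this double-bonded ring carbon, such as a carboxylic acid or an open-chain amine, would move the number beyond the scatter.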